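The compounds below may be only part of what the source reports. "The series", "measured", "known", "first", "only" and "open" are said of these compounds alone.

Measured so far:
compound 1 `[N-]=[N+]=N[C@]1(CO)O[C@@H](n2ccc(N)nc2=O)[C@H](O)[C@H]1O` — < 100000 nM
compound 2 `[N-]=[N+]=N[C@]1(CO)O[C@@H](n2ccc(N)nc2=O)[C@@H](O)[C@@H]1O` — < 1000000 nM

In an ADME assay on WST1 cells (Homo sapiens) for cytotoxicity, read by WST assay (a lower number here means that less compound is tolerated, a higher number that more compound is tolerated), compound 2 reaches only a limit, < 1000000 nM. Compound 1 likewise gives only a limit, < 100000 nM. Among the measured compounds shown here, the step that the two limits leave unreadable from compound 1 to compound 2 is thus not readable, and it is the sole measured step bearing on the next change. Compound 3 `[N-]=[N+]=N[C@]1(CO)O[C@@H](n2ccc(N)nc2=O)[C@H](O)[C@@H]1O` differs from compound 2 in that (the two compounds have the same atoms and bonds; at least one stereo element is drawn with a configuration in one of them and without one in the other: 1 of 5 stereo elements differ; a stereocentre at a saturated ring carbon is drawn S in compound 2 and R in compound 3). With both neighbours sitting at limits, no direction beyond the scatter can be expected from the change. Compound 3 is expected near 100000 nM, in the range 20000 nM to 1000000 nM. The expected step is a step that the limit leaves unreadable from compound 2 to compound 3, and a limit rather than a number is the likely outcome.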

Compound 3, half-maximal cytotoxic concentration: < 2000000 nM
Compound 3 ended at the assay's limit; the forecaster's own chance of this, stated with the estimate: 70%; the middle value does not contradict the limit.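

Among the compounds shown here, compound 1, compound 2 and compound 3 each give only a limit in this assay, so no step among them can be read. From the compounds shown here alone, whether the configuration at the differing ring carbons changes the tolerated concentration stays open.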